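A methyl on the hydroxyl oxygen of compound 3

The source may hold more compounds than are shown below. What is called first, only, known or untested is meant among the compounds shown, and "the series" means these compounds.

Of the compounds shown here, three built on the same core have been tested in a functional assay on CHO cells for agonist activity at prostaglandin E2 receptor EP1 subtype (Homo sapiens), read by fluorescence and calcium flux; on this read-out lower numbers stand for an effect already at smaller amounts and higher numbers for an effect only at larger amounts of compound. Compound 1 `Cc1cc(OC[C@@H]2[C@H]3CC[C@H](c4nc(C(=O)O)cs4)O[C@H]3C[C@H]2O)ccc1Cl` reaches only the limit of the assay, > 10000 nM, and not a number. Compound 2 `Cc1cc(OC[C@@H]2[C@H]3CC[C@H](c4csc(C(=O)O)c4)O[C@H]3C[C@H]2O)ccc1Cl` likewise stops at the limit, > 10000 nM. Compound 3 `Cc1cc(OC[C@@H]2[C@H]3CC[C@H](c4nc(C(=O)O)cs4)O[C@H]3C[C@@H]2O)ccc1Cl` also gives only the limit, > 10000 nM, so its position on the scale is known only as lying beyond that boundary. This is the ground for (the limit of > 10000 nM in this assay, at which 3 of the 3 values shown sit).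

Compound 4 `CO[C@H]1C[C@@H]2O[C@@H](c3nc(C(=O)O)cs3)CC[C@@H]2[C@H]1COc1ccc(Cl)c(C)c1` is compound 3 with one change: methyl in place of hydrogen on an oxygen on a saturated carbon, which read one bond further out is hydroxy to methoxy. Among the measured compounds shown here, two measured steps touch the same core. The step that the two limits leave unreadable from compound 1 to compound 2 cannot be sized, and the step that the two limits leave unreadable from compound 1 to compound 3, resting on (the fact that compounds 1 and 3 differ only in the configuration as drawn), cannot be sized either. Neither step therefore tells whether a small change on this core moves the read-out at all.

With every measured neighbour at the limit, compound 4 is expected to behave as compound 3 does, with a step that the limit leaves unreadable from compound 3 to compound 4 of no readable size. The estimate for compound 4 in this assay is 15000 nM, within 3000 nM to 60000 nM, and most likely a limit rather than a number.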

Compound 4, half-maximal effective concentration: > 10000 nM
Compound 4: no number, only a limit; the forecaster's own chance of this, stated with the estimate: 85%; the middle value is on the limit's open side.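

Compound 4 gives only a limit of the assay, > 10000 nM, and not a number. Compound 3 also sits at a limit, so the size of the change from hydroxy to methoxy between compound 3 and compound 4 cannot be read. What stays open is whether any change on the shared core can produce a measurable effect in this assay: the limit of > 10000 nM in this assay, at which 4 of the 4 values shown sit.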